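This account rests on a few compounds, and the source may have more. Where it says the series, first, only, none or still open, it means among the compounds named here.

In a functional assay on SNB-19 cells (Homo sapiens) for inhibition, read by sulforhodamine B assay, with a stated time of 48 h (a lower number here means a stronger inhibitor of growth, a higher number a weaker inhibitor of growth), compound 1 `Cc1ccc(NC(=O)/C=C/c2ccccc2)c(C(N)=O)c1` gives 5690 nM. Among the compounds with values here, compound 2 `NC(=O)c1cc(I)ccc1NC(=O)/C=C/c1ccccc1` gives 586 nM, the lower of the only two numbers available, which makes it the stronger inhibitor of growth of this pair. Putting iodo in place of methyl on an aromatic carbon accounts for the difference, a 9.7-fold lower number from compound 1 to compound 2 (0.99 log units; beyond the scatter), and this gap is beyond the usual scatter.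

Compound 3 `NC(=O)c1cc(I)ccc1NC(=O)/C=C/c1ccccc1Cl` is compound 2 with a single change: chloro in place of hydrogen on an aromatic carbon. Chloro takes the place of hydrogen on an aromatic carbon, ortho to a large group, so phenyl becomes 2-chlorophenyl.

Within the data shown here, only one measured step can guide the expectation, and it bears on this change only loosely. Among the measured compounds shown here, the step to compound 2, a 9.7-fold lower number from compound 1 to compound 2 (0.99 log units; beyond the scatter), swapped a different group at a different place, and no measured compound carries a substituent on the phenyl. With so little evidence, no clear shift in this assay can be predicted, and the expected change stays within the scatter, with a slight lean towards a lower number. The estimated step is a 1.3-fold lower number from compound 2 to compound 3 (0.11 log units; within the scatter). The expected value for compound 3 is 450 nM, within an estimated range of 130 nM to 1500 nM.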

Compound 3, concentration for 50% growth inhibition: 1410 nM
Compound 3: the middle estimate sits 3.1-fold (0.50 log units) below what was measured, and the stated range covers the measured number.
By their numbers in this assay, from the lowest: compound 2; then compound 3; then compound 1.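

Within the data shown here, compound 3 is the first compound here with anything added to the phenyl, and in this assay the change to 2-chlorophenyl gives a 2.4-fold higher number from compound 2 to compound 3 (0.38 log units; beyond the scatter). This shows that the phenyl is not a silent part of the molecule: one added chlorine, ortho to a large group, moves the number beyond the usual scatter. The shift runs towards a weaker inhibitor of growth, so at this position chloro is a modest step backwards from hydrogen, and the data offer no measurement that accounts for it.

As far as these compounds go, whether this loss belongs to chloro itself or to the place it occupies on the phenyl remains open. A methoxy group or an amine on the same carbon, or chloro moved to a different carbon of the phenyl, would help separate those two readings and show whether any substituent on this ring can match or improve on the plain phenyl of compound 2.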